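The compounds below may be only part of what the source reports. "The series", "measured", "known", "first", "only" and "open" are said of these compounds alone.

Measured so far:
- compound 1, `C[C@H](Oc1ccc(S(C)(=O)=O)cc1C(=O)N1Cc2ccc(N3CCN(C)CC3)cc2C1)C(F)(F)F`: in an assay on CHO cells for inhibition of sodium- and chloride-dependent glycine transporter 1 (Homo sapiens), read by scintillation counting (on this read-out lower numbers stand for an effect already at smaller amounts and higher numbers for an effect only at larger amounts of compound), compound 1 gives 2080 nM
- compound 2, `Cc1cccc2c1CN(C(=O)c1cc(S(C)(=O)=O)ccc1O[C@@H](C)C(F)(F)F)C2`: in this assay compound 2 gives 3360 nM
- compound 3, `C[C@H](Oc1ccc(S(C)(=O)=O)cc1C(=O)N1Cc2cc(C(F)(F)F)cnc2C1)C(F)(F)F`: in this assay compound 3 gives 50 nM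

Compound 1 stands second highest of the three numbers. Compound 2 is its nearest neighbour, with a number that sits within the usual scatter of compound 1, so no order between the two can be claimed. Compound 3 is furthest away, with a number far lower than that of compound 1, well beyond the scatter; its core differs from that of compound 1 in more than one place, so no single change accounts for the gap.

Compound 4, `C[C@H](Oc1ccc(S(C)(=O)=O)cc1C(=O)N1Cc2ccc(C3CCOCC3)cc2C1)C(F)(F)F`, differs from compound 1 in one place: oxan-4-yl in place of 4-methylpiperazin-1-yl on an aromatic carbon. Among the compounds with values here, no measured pair shows this exchange, so there is nothing to lean on for its size or direction. The expectation is a step of a 1.4-fold lower number from compound 1 to compound 4 (0.14 log units; within the scatter) of no more than modest size, not clearly beyond the scatter in either direction. Compound 4 is therefore estimated at 1500 nM, in the range 400 nM to 6000 nM.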

Compound 4, half-maximal effective concentration: 14 nM
Compound 4: middle estimate off by 110-fold (2.03 log units), on the high side; the whole stated range lies above it.
By their numbers in this assay, from the lowest: compound 4; then compound 3; then compounds 1 and 2 (each within the scatter of the next).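

Within the data shown here, the aromatic carbon of the carbon-only ring, para to a fused ring, is sensitive to the group it carries: in this assay the exchange of 4-methylpiperazin-1-yl for oxan-4-yl gives a 150-fold lower number from compound 1 to compound 4 (2.17 log units; beyond the scatter) and is the first single-place step available. The size of this step shows that the choice of hetero atoms can matter greatly here, since both groups are six-membered non-aromatic rings without net charge. No measurement of any property accompanies the step, so its origin remains unassigned.

As far as these compounds go, whether the step tracks the ring nitrogens, the ring oxygen or the ring as a whole remains open. A piperidin-4-yl or cyclohexyl ring on the same carbon would help to separate these possibilities.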